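The source may report more compounds than this note shows. Statements on the series, on what has been measured and on what is new or still open speak of the compounds shown alone.

Two members of the series carry numbers in a functional assay on SNB-19 cells (Homo sapiens) for inhibition, read by sulforhodamine B assay, with a stated time of 48 h, tested at 10 uM; on this read-out lower numbers stand for less inhibition and higher numbers for more inhibition at the one concentration tested (going by the name of the read-out). Compound 1 `Brc1cn2ccnc2c(-c2ccc3ncn(C4CCCCC4)c3c2)n1` gives 8.09%. Among the measured compounds shown here, compound 2 `CC(=O)c1ccc(-c2cn3ccnc3c(-c3ccc4ncn(C5CCCCC5)c4c3)n2)cc1` gives 3.96%, the lowest of the two numbers, with compound 1 nearest and within the scatter of it; the single measured step, a number 4.1 percentage points lower from compound 1 to compound 2 (within the scatter), does not rise above the scatter. Compound 3 `Fc1ccccc1-c1cn2ccnc2c(-c2ccc3ncn(C4CCCCC4)c3c2)n1` differs from compound 2 by 2-fluorophenyl in place of 4-acetylphenyl on an aromatic carbon. For the measured compounds named here, the one step bearing on this position, 4-acetylphenyl in place of bromo, stayed within the scatter, so no step beyond the scatter is expected in this assay; the expected step is a number 2 percentage points higher from compound 2 to compound 3 (within the scatter). Compound 3 is estimated at 6%, between -6% and 20%.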

Compound 3, a percentage reported as inhibition, at one concentration (the size of the read-out at that concentration, not a potency): 7.56%
Beside the measured number, compound 3's estimate is 1.6 percentage points below it, and the stated range covers the measured number.
By their numbers in this assay, from the lowest: compounds 2, 3 and 1 (each within the scatter of the next).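

In this assay, the change at this aromatic carbon from 4-acetylphenyl to 2-fluorophenyl gives a number 3.6 percentage points higher from compound 2 to compound 3 (within the scatter), and the change from bromo to 2-fluorophenyl gives a number 0.5 percentage points lower from compound 1 to compound 3 (within the scatter). Bromo and two differently substituted phenyl groups, one with a carbonyl and one with fluorine, are therefore not told apart at this position at the one concentration tested. Nothing available accounts for this. From the compounds shown here alone, whether an amine, a carboxylic acid or a longer chain at this carbon would move the number beyond the scatter remains open.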